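Swapping Chloro for Methoxy on the Methylated Compound

The source may report more compounds than this note shows. Statements on the series, on what has been measured and on what is new or still open speak of the compounds shown alone.

Among the three compounds measured in a functional assay on SK-MEL-5 cells (Homo sapiens) (a higher number here means a weaker inhibitor of growth, a lower number a stronger inhibitor of growth), compound 3 (`Cc1cnc2nc(-c3ccc(Cl)cc3)cc(O)c2c1`) stands lowest at 2190 nM while compound 2 (`Oc1cc(-c2ccc(Cl)cc2)nc2ncccc12`) gives 28800 nM and compound 1 (`COc1ccc(-c2cc(O)c3cccnc3n2)cc1`) gives 34700 nM as its result. The next compound, compound 4 (`COc1ccc(-c2cc(O)c3cc(C)cnc3n2)cc1`), keeps the methyl of compound 3 and has methoxy in place of chloro on an aromatic carbon.

Going by the values given here, two measured steps bear on this. The same exchange, run in the opposite direction and without the methyl, gave a 1.2-fold lower number from compound 1 to compound 2 (0.08 log units; within the scatter) and so made no clear difference. The methyl itself gave a 13-fold lower number from compound 2 to compound 3 (1.12 log units; beyond the scatter) and that large gain is shared by compound 3 and compound 4. The exchange has been measured only once, so it may not behave the same way alongside the methyl. The expected result is therefore no step beyond the scatter, with a 1.2-fold higher number from compound 3 to compound 4 (0.07 log units; within the scatter) as the estimated change. Compound 4 is estimated at 2600 nM with an expected range from 1000 nM to 7000 nM once it is measured.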

Compound 4, concentration for 50% growth inhibition: 3720 nM
For compound 4 the middle estimate is 1.4-fold (0.16 log units) below the measured one; the range from low to high includes it.
By their numbers in this assay, from the lowest: compounds 3 and 4 (each within the scatter of the next); then compounds 2 and 1 (each within the scatter of the next).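

With the methyl present, the exchange on the aromatic carbon para to a large group remains small, a 1.7-fold higher number from compound 3 to compound 4 (0.23 log units; within the scatter), so chloro and methoxy give results within the scatter of each other on both cores: the same change on two cores in this assay, a 1.2-fold lower number (0.08 log units; within the scatter) from compound 1 to compound 2 and a 1.7-fold lower number (0.23 log units; within the scatter) from compound 4 to compound 3, 1.4-fold (0.15 log units) apart, within the scatter of two such steps. The methyl now also has a second reading, on the methoxy compounds, a 9.3-fold lower number from compound 1 to compound 4 (0.97 log units; beyond the scatter), and its size agrees with the step seen on the chloro compounds: the same change on two cores in this assay, a 13-fold lower number (1.12 log units; beyond the scatter) from compound 2 to compound 3 and a 9.3-fold lower number (0.97 log units; beyond the scatter) from compound 1 to compound 4, 1.4-fold (0.15 log units) apart, within the scatter of two such steps. Across these four compounds, the steps beyond the scatter in this assay all come from the methyl and none from the exchange.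

Chloro and methoxy are only two groups, so it remains open whether an amine or a carboxylic acid at the same place would give a step beyond the scatter. On these data alone, it is also open whether an ethyl group in place of the methyl would lower the number further.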